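This account rests on a few compounds, and the source may have more. Where it says the series, first, only, none or still open, it means among the compounds named here.

Measured compounds:
- compound 1, `ClCc1ccccc1Cn1cnc2c(Cl)nc(Cl)nc21`: in a functional assay on EKVX cells (Homo sapiens) for cytotoxicity, read by sulforhodamine B assay, with a stated time of 48 h (on this read-out higher numbers stand for weaker inhibition of growth and lower numbers for stronger inhibition of growth), compound 1 gives 1770 nM
- compound 2, `ClCc1ccccc1Cn1cnc2c(Cl)ncnc21`: in this assay compound 2 gives 3090 nM
- compound 3, `ClCc1cccc(Cn2cnc3c(Cl)ncnc32)c1`: in this assay compound 3 gives 18600 nM

Compound 3 has the highest number of the three; the gaps to compound 2 and to compound 1 are both beyond the scatter. Compound 2 and compound 3 share the same atoms joined differently; the difference between the two cores is not broken down here.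

Compound 1 differs from compound 2 by chloro in place of hydrogen on an aromatic carbon. This change gives a 1.7-fold lower number from compound 2 to compound 1 (0.24 log units; within the scatter), a step that stays within the scatter.

Compound 4, `ClCc1cccc(Cn2cnc3c(Cl)nc(Cl)nc32)c1`, is not yet measured. It differs from compound 3 by chloro in place of hydrogen on an aromatic carbon, the same change as from compound 2 to compound 1, at a place described in the same words. Among the measured compounds shown here, only one prior example of this change exists, and it falls within the scatter, so the expectation for compound 4 rests on that single step.

For compound 4 in this assay the expected step is a 1.7-fold lower number from compound 3 to compound 4 (0.23 log units; within the scatter), resting on compound 1 versus compound 2 (a 1.7-fold lower number from compound 2 to compound 1 (0.24 log units; within the scatter)) and on the starting point of compound 3 (18600 nM). The estimate for compound 4 is 11000 nM, expected between 4500 nM and 28000 nM.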

Compound 4, concentration for 50% growth inhibition: 1730 nM
Compound 4: the middle estimate sits 6.4-fold (0.80 log units) above what was measured; the whole stated range lies above it.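

Setting chloro in place of hydrogen on the aromatic carbon between two ring nitrogen atoms gives an 11-fold lower number from compound 3 to compound 4 (1.03 log units; beyond the scatter) in this assay, and this step does not match the one seen on the other core: the same change on two cores in this assay, a 1.7-fold lower number (0.24 log units; within the scatter) from compound 2 to compound 1 and an 11-fold lower number (1.03 log units; beyond the scatter) from compound 3 to compound 4, 6.2-fold (0.79 log units) apart, beyond the scatter of two such steps

Among the compounds shown here, only the step on the core of compound 3 lies beyond the scatter, so a shared direction across the two cores cannot be claimed. With one pair per core, the size of this change differs between two cores made of the same atoms joined differently, but the pairs give neither a reason for that difference nor a rule for any further core.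

Open, from the compounds shown here alone, is whether an amine or a methoxy group at that same carbon would follow either step, and whether the gap between the two steps persists when the chloromethyl group gives way to a hydroxymethyl group. Going by these compounds, all four compounds are read on one cell line, so the behaviour of this change on other cell lines also remains open.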